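The compounds below may be only part of what the source reports. "The series", "measured", "known", "first", "only" and "open" are said of these compounds alone.

Compound 1 `CC1C(=O)N(CCCCCOc2ccc(Cl)cc2)/C(=N\C#N)N1c1ccncc1` gives 3680 nM in a functional assay on HONE1 cells for cytotoxicity against HONE1 cell line (Homo sapiens); on this read-out higher numbers stand for weaker inhibition and lower numbers for stronger inhibition.
Compound 2 `CC1C(=O)N(CCCCCCOc2ccc(Cl)cc2)/C(=N\C#N)N1c1ccncc1` gives 303 nM in this assay.
Compound 3 `N#C/N=C1\N(CCCCCCOc2ccc(Cl)cc2)C(=O)C(c2ccccc2)N1c1ccncc1` gives 337 nM in this assay.

Compound 1 and compound 2 share a core and differ in one place: (4-chlorophenoxy)methyl in place of 4-chlorophenoxy on a saturated chain carbon, five bonds along the chain from an amide-type nitrogen in a ring. This brings a 12-fold lower number from compound 1 to compound 2 (1.08 log units; beyond the scatter). Compound 2 and compound 3 differ by phenyl in place of methyl on a saturated ring carbon, and this brings a 1.1-fold higher number from compound 2 to compound 3 (0.05 log units; within the scatter). Between compound 1 and compound 3 the difference is not broken down here.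

Compound 4 `N#C/N=C1\N(CCCCCCCOc2ccc(Cl)cc2)C(=O)C(c2ccccc2)N1c1ccncc1` has not been measured in this assay. It differs from compound 3 in one place: (4-chlorophenoxy)methyl in place of 4-chlorophenoxy on a saturated chain carbon, six bonds along the chain from an amide-type nitrogen in a ring. Going by the values given here, this is the same kind of change as the one from compound 1 to compound 2, though the place is not the same: there it sat five bonds along the chain from an amide-type nitrogen in a ring, here six bonds along. A single step of this kind cannot show whether a further lengthening helps again, so the expectation rests loosely on compound 1 and compound 2 with a 12-fold lower number from compound 1 to compound 2 (1.08 log units; beyond the scatter). For compound 4 the expected step is a 1.3-fold lower number from compound 3 to compound 4 (0.13 log units; within the scatter). Compound 4 is estimated at 250 nM in this assay, within 60 nM to 1000 nM.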

Compound 4, half-maximal inhibitory concentration: 398 nM
Compound 4: middle estimate off by 1.6-fold (0.20 log units), on the low side, and the stated range covers the measured number.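

In this assay, the change from 4-chlorophenoxy to (4-chlorophenoxy)methyl brings a 1.2-fold higher number from compound 3 to compound 4 (0.07 log units; within the scatter), so the large drop seen on the core of compound 1 does not carry over to the core of compound 3. Set side by side, the two steps of this kind differ: the same change on two cores in this assay, a 12-fold lower number (1.08 log units; beyond the scatter) from compound 1 to compound 2 and a 1.2-fold higher number (0.07 log units; within the scatter) from compound 3 to compound 4, 14-fold (1.16 log units) apart, beyond the scatter of two such steps

This does not show what sets them apart: the two steps differ both in the core, with methyl or phenyl on the saturated ring carbon, and in the place, five or six bonds along the chain from the amide-type nitrogen, and the compounds shown cannot separate these two differences.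

On these data alone, it remains open how the methyl core would respond to the chain of compound 4, and how the phenyl core would respond to the shorter chain of compound 1. As far as these compounds go, it is also open whether a still longer chain, or an amine or a carboxylic acid in place of the chlorine, would move the number in this assay.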